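A Methyl Added to Compound 3

A few compounds are considered here, and "the series" means these few. Any claim that something is new, unique, unknown or untested is made for them only; others in the source may bear on it.

In an ADME assay on MT4 cells (Homo sapiens) for cytotoxicity, read by MTT assay (on this read-out higher numbers stand for lower toxicity in this test and lower numbers for higher toxicity in this test), compound 3 `Cc1cc(C)cc(S(=O)(=O)c2c(C(=O)NCc3cccc(O)c3)[nH]c3ccc(Cl)cc23)c1` gives 27000 nM, level within the scatter with compound 1 `Cc1cc(C)cc(S(=O)(=O)c2c(C(=O)Nc3ccccc3O)[nH]c3ccc(Cl)cc23)c1` at 19700 nM and compound 2 `Cc1cc(C)cc(S(=O)(=O)c2c(C(=O)Nc3ccc(O)cc3)[nH]c3ccc(Cl)cc23)c1` at 18100 nM. Compound 4 `Cc1cc(C)cc(S(=O)(=O)c2c(C(=O)NC(C)c3cccc(O)c3)[nH]c3ccc(Cl)cc23)c1` carries methyl in place of hydrogen on a saturated chain carbon bound to an amide-type nitrogen and an aromatic carbon. For the measured compounds named here, no measured step tests this methyl directly. The closest evidence comes from swapping the group on the amide-type nitrogen: a 1.1-fold lower number from compound 1 to compound 2 (0.04 log units; within the scatter), a 1.4-fold higher number from compound 1 to compound 3 (0.14 log units; within the scatter) and a 1.5-fold higher number from compound 2 to compound 3 (0.17 log units; within the scatter), all within the scatter. The expected step, a 1.1-fold lower number from compound 3 to compound 4 (0.03 log units; within the scatter), therefore stays within the scatter, with no clear direction. Compound 4 is expected at 25000 nM, with an estimated range of 12000 nM to 50000 nM.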

Compound 4, half-maximal cytotoxic concentration: 16000 nM
For compound 4 the middle estimate is 1.6-fold (0.19 log units) above the measured one; low and high end bracket the measured number.
By their numbers in this assay, from the lowest: compounds 4, 2, 1 and 3 (each within the scatter of the next).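

In this assay the first direct test of this methyl on the saturated chain carbon gives a 1.7-fold lower number from compound 3 to compound 4 (0.23 log units; within the scatter) and so shows that adding this one carbon leaves the number within the scatter. The wider swaps on the amide-type nitrogen give a 1.1-fold lower number from compound 2 to compound 4 (0.05 log units; within the scatter) and a 1.2-fold lower number from compound 1 to compound 4 (0.09 log units; within the scatter) and also stay within the scatter, so compound 4 sits level with all three earlier compounds. No measurement shown here offers an explanation for this result.

Still open, on these data alone, is whether an ethyl group, an amine or a carboxylic acid on this same carbon would move the number beyond the scatter.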